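Swapping the aryl substituent on an acylguanidine core

The source may report more compounds than this note shows. Statements on the series, on what has been measured and on what is new or still open speak of the compounds shown alone.

Measured so far:
compound 1, `Cc1cc(C2CCCCC2)c(S(C)(=O)=O)cc1C(=O)N=C(N)N`: 22 nM
compound 2, `Cc1cc(Sc2ccccc2)c(S(C)(=O)=O)cc1C(=O)N=C(N)N`: 14 nM
compound 3, `Cc1cc(N2CCC(N)CC2)c(S(C)(=O)=O)cc1C(=O)N=C(N)N`: 9.8 nM

The three measured compounds share one core and differ only in the group on one aromatic carbon. For the measured compounds named here, in a functional assay for inhibition of sodium/hydrogen exchanger (Oryctolagus cuniculus) (on this read-out lower numbers stand for stronger inhibition and higher numbers for weaker inhibition), compound 3 gives the lowest of the three numbers, but the gap to compound 2 is within the scatter, so it cannot be set apart from compound 2; only the step of a 2.2-fold lower number from compound 1 to compound 3 (0.35 log units; beyond the scatter) is beyond the scatter, and that one is modest.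

Compound 4, `Cc1cc(Nc2ncccn2)c(S(C)(=O)=O)cc1C(=O)N=C(N)N`, differs from compound 3 at the same position: (pyrimidin-2-yl)amino in place of 4-aminopiperidin-1-yl on an aromatic carbon.

Every step measured so far changes the group at this position, and every one of them is small: a 1.6-fold lower number from compound 1 to compound 2 (0.20 log units; within the scatter), a 2.2-fold lower number from compound 1 to compound 3 (0.35 log units; beyond the scatter), a 1.4-fold lower number from compound 2 to compound 3 (0.15 log units; within the scatter). Cyclohexyl, phenylsulfanyl and 4-aminopiperidin-1-yl thus all land close together in this assay. Nothing in the measured set says whether a (pyrimidin-2-yl)amino group behaves differently, so the expectation is drawn from the narrow spread seen so far, with a wide range to cover the unknown.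

Compound 4 is therefore expected to lie near compound 3, with a step of a 1.5-fold higher number from compound 3 to compound 4 (0.18 log units; within the scatter), that is no step beyond the scatter. The estimate for compound 4 is 15 nM, with a range from 5 nM to 45 nM.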

Compound 4, half-maximal inhibitory concentration: 8.3 nM
Compound 4: the middle estimate sits 1.8-fold (0.26 log units) above what was measured; the measured number falls inside the stated range.
By their numbers in this assay, from the lowest: compounds 4, 3, 2 and 1 (each within the scatter of the next, the first and the last beyond it).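

In this assay, putting the aromatic (pyrimidin-2-yl)amino in place of the non-aromatic 4-aminopiperidin-1-yl, on the aromatic carbon ortho to a methylsulfonyl group, changes little (a 1.2-fold lower number from compound 3 to compound 4 (0.07 log units; within the scatter)). A six-membered aromatic ring with 2 hetero atoms therefore fits the same narrow band as the earlier groups, and compound 4 cannot be set apart from the phenylsulfanyl compound either (a 1.7-fold lower number from compound 2 to compound 4 (0.23 log units; within the scatter)), while its only gap beyond the scatter is the modest one to the cyclohexyl compound (a 2.7-fold lower number from compound 1 to compound 4 (0.42 log units; beyond the scatter)). Across these four compounds, neither the ring type nor the linking atom opens a large difference at this position, and nothing available accounts for that narrow spread.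

What remains open is whether the position stays this permissive with a carboxylic acid, a longer alkyl chain or a lone hydrogen, groups that differ far more from those shown than these do from one another. It is also open whether the close agreement among these groups would hold on a different core or in any other read-out.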